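The compounds below may be only part of what the source reports. "The series", "measured", "known", "first", "only" and "open" are said of these compounds alone.

Compound 1: `COc1cc2c(Oc3ccc(NC(=O)c4nn(-c5ccccc5)c(=O)cc4C)cc3F)ccnc2cc1OCCCN1CCN(C)CC1`, 270 nM
Compound 2: `COc1cc2c(Oc3ccc(NC(=O)c4nn(-c5cccc(F)c5)c(=O)cc4C)cc3F)ccnc2cc1OCCCN1CCCCC1`, 290 nM

Both were tested in a functional assay on HT-29 cells (Homo sapiens) for inhibition, read by MTT assay, with a stated time of 72 h; a lower number here means a stronger inhibitor, a higher number a weaker inhibitor. Compound 2 gives 290 nM there, and compound 1 gives 270 nM; the two values lie within the scatter of each other, so neither stands apart from the other. Compound 3, `COc1cc2c(Oc3ccc(NC(=O)c4nn(-c5cccc(F)c5)c(=O)cc4C)cc3F)ccnc2cc1OCCCN1CCN(C)CC1`, has not yet been measured. It differs from compound 2 in one place: 4-methylpiperazin-1-yl in place of piperidin-1-yl on a saturated chain carbon, three bonds along the chain from an oxygen on an aromatic ring. Compound 1 already carries the 4-methylpiperazin-1-yl group, and its 270 nM sits beside the value of compound 2, so the data give no sign that this exchange moves the number far. The exchange is therefore expected to be small, a 1.0-fold lower number from compound 2 to compound 3 (0.02 log units; within the scatter), with no direction beyond the scatter. Compound 3 is estimated at 280 nM, within a range from 140 nM to 560 nM.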

Compound 3, half-maximal inhibitory concentration: 250 nM
The estimate for compound 3 lay 1.1-fold (0.05 log units) above the measured number; the range from low to high includes it.
By their numbers in this assay, from the lowest: compounds 3, 1 and 2 (each within the scatter of the next).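

In this assay, the exchange of piperidin-1-yl for 4-methylpiperazin-1-yl on a saturated chain carbon, three bonds along the chain from an oxygen on an aromatic ring, can now be read directly with the rest of the structure held constant: it gives a 1.2-fold lower number from compound 2 to compound 3 (0.06 log units; within the scatter), so this change does not separate the two groups in this assay. With the 4-methylpiperazin-1-yl group kept, fluoro in place of hydrogen on an aromatic carbon gives a 1.1-fold lower number from compound 1 to compound 3 (0.03 log units; within the scatter), so that change does not separate the two compounds either. No measurement shown here offers an explanation for these results. 

From the compounds shown here alone, whether a morpholine or a dimethylamino group at the end of the chain, or a longer chain, would give a different number remains open. So does the effect of a chloro or methoxy group in place of the fluoro.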